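The source may hold more compounds than are shown below. What is called first, only, known or untested is meant among the compounds shown, and "the series" means these compounds.

Measured so far:
compound 1 `OCCCCCC(O)c1ccc(-c2ccc(Br)cc2)cc1`: 20000 nM
compound 2 `Cc1ccccc1-c1ccc(C(O)CCCCCO)cc1`: 24000 nM
compound 3 `OCCCCCC(O)c1ccc(-c2ccc(Cl)cc2Cl)cc1`: 8000 nM

These three compounds share a core and were tested in a functional assay on J774 cells (Mus musculus) for cytotoxicity, read by resazurin assay; a lower number here means a stronger inhibitor, a higher number a weaker inhibitor. Compound 1 sits second highest of the three numbers. Its nearest neighbour is compound 2, reached by a 1.2-fold higher number from compound 1 to compound 2 (0.08 log units; within the scatter), a change that swaps one substituted phenyl ring for another without moving the number beyond the scatter. Compound 3, with two chloro groups on its outer ring, gives a lower number than compound 1, and that gap does lie beyond the scatter, so the outer ring is not wholly indifferent.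

Compound 4 `CN(C)c1ccc(-c2ccc(C(O)CCCCCO)cc2)cc1` has not yet been measured in this assay. It differs from compound 1 in one place: dimethylamino in place of bromo on an aromatic carbon. Going by the values given here, only the step from compound 1 to compound 2 bears on this change, since it too alters the group on the outer ring, and that step stayed within the scatter. Among the compounds with values here, no measured step replaces a halogen with a dimethylamino group, so a direct guide is missing. The expectation is therefore a small movement, a 1.1-fold higher number from compound 1 to compound 4 (0.04 log units; within the scatter), within the scatter. Compound 4 is estimated to give 22000 nM, with a range from 8000 nM to 60000 nM.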

Compound 4, half-maximal inhibitory concentration: 28000 nM
Compound 4: the middle estimate sits 1.3-fold (0.10 log units) below what was measured, within the range that was stated.
By their numbers in this assay, from the lowest: compound 3; then compounds 1, 2 and 4 (each within the scatter of the next).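

Read in this assay, the swap of bromo for dimethylamino gives a 1.4-fold higher number from compound 1 to compound 4 (0.15 log units; within the scatter), so this is the first step in which the group on this aromatic carbon, para to a large group, is replaced while the rest of compound 1 stays the same. The entering group is larger by count, with three heavy atoms against one, and it brings a hydrogen-bond acceptor and nitrogen where the halogen stood, yet the two compounds cannot be told apart in this measurement. A single halogen at this carbon is therefore not required to keep the number where it stands, although one pair of compounds shows this for only one replacement, and nothing measured here speaks to why the result came out this way.

The compounds shown leave open whether a carboxylic acid, a primary amine or a nitrile on this same carbon would also stay within the scatter of compound 1. They also leave open what a longer chain on the shared core would do, since all the compounds here carry the same chain.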